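Aryl swap on the shared core: expectation for compound 4

The compounds below may be only part of what the source reports. "The series", "measured", "known", "first", "only" and "open" are said of these compounds alone.

Compound 1 `CCCOC(=O)C1=C(C)NC(=S)NC1c1ccco1` gives 1% in an assay on membranes from CHO cells for displacement of a labelled ligand from adenosine receptor A1 (Homo sapiens), read by scintillation counting, with a stated time of 60 min, tested at 1 uM; on this read-out higher numbers stand for more inhibition at the one concentration tested (going by the name of the read-out) and lower numbers for less inhibition.
Compound 2 `CC1=C(C(=O)OC(C)(C)C)C(c2ccco2)NC(=S)N1` gives 3%.
Compound 3 `CC1=C(C(=O)OCc2ccccc2)C(c2ccco2)NC(=S)N1` gives 32%.

Compound 1 holds the lowest number of the three: compound 2 sits a number 2 percentage points higher from compound 1 to compound 2 (within the scatter), compound 3 sits a number 31 percentage points higher from compound 1 to compound 3 (beyond the scatter). Compound 4 `CCCOC(=O)C1=C(C)NC(=S)NC1c1ccsc1` differs from compound 1 by thiophen-3-yl in place of furan-2-yl on a saturated ring carbon. Every measured step concerns the ester side of the core: a number 2 percentage points higher from compound 1 to compound 2 (within the scatter), a number 31 percentage points higher from compound 1 to compound 3 (beyond the scatter) and a number 29 percentage points higher from compound 2 to compound 3 (beyond the scatter). Among the measured compounds shown here, none alters the aryl group on the saturated ring carbon, so no measured step bears on this change. With no guidance from the data, the expectation is no step beyond the scatter, a number 4 percentage points higher from compound 1 to compound 4 (within the scatter). Compound 4 is estimated at 5% in this assay, with a range from 0% to 20%.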

Compound 4, a percentage reported as inhibition, at one concentration (the size of the read-out at that concentration, not a potency): 5%
Beside the measured number, compound 4's estimate shows no gap at the digits printed; measured number inside the range.
By their numbers in this assay, from the lowest: compounds 1, 2 and 4 (each within the scatter of the next); then compound 3.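

Among the compounds shown here, the first change at the aryl group on the saturated ring carbon, thiophen-3-yl in place of furan-2-yl, gives in this assay a number 4 percentage points higher from compound 1 to compound 4 (within the scatter). With the propoxycarbonyl group in place, this swap of ring hetero atom therefore moves the read-out no further than the ester change to tert-butyl does, and only the benzyl ester has so far produced a step beyond the scatter. Nothing available gives a reason for this result.

Going by these compounds, since compound 1 already reads near the bottom of the scale, a loss at this position could hardly show here, so the same swap on the benzyl ester of compound 3 stays open. Also open, on these data alone, is what a phenyl or cyclohexyl group would do on the saturated ring carbon.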